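The compounds below may be only part of what the source reports. "The series", "measured", "known", "first", "only" and "open" are said of these compounds alone.

Measured compounds:
Compound 1 `N#Cc1cc2cc(-c3ccccc3)n(O)c2cc1C#N` gives 10300 nM in an assay on isolated protein for inhibition of Amine oxidase [flavin-containing] B (Homo sapiens), read by fluorescence and spectrophotometry, with a stated time of 20 min; a lower number here means a stronger inhibitor, a higher number a weaker inhibitor.
Compound 2 `Cc1ccc(-c2cc3cc(C#N)c(C#N)cc3n2O)cc1` gives 821 nM in this assay.
Compound 3 `O=C(O)c1cc2cc(-c3ccccc3)n(O)c2cc1C(=O)O` gives 56200 nM in this assay.

Compound 3 carries the highest number of the three. How the core of compound 3 differs from the core of compound 1 is not broken down here; the two values alone show compound 3 as the weaker of that pair. Compound 1 and compound 2 differ in one place, (methyl in place of hydrogen on an aromatic carbon), and the step between them is a 13-fold lower number from compound 1 to compound 2 (1.10 log units; beyond the scatter). Compound 4 `Cc1ccc(-c2cc3cc(C(=O)O)c(C(=O)O)cc3n2O)cc1` has not yet been measured. It stands to compound 3 as compound 2 stands to compound 1: methyl in place of hydrogen on an aromatic carbon. The two place descriptions read the same word for word, so this is the same change made on a different core; it occurs twice among the compounds shown. Whether a step seen once carries over to a second core is uncertain, so the expected step is set somewhat below the earlier one. Compound 4 is expected to show an 8.6-fold lower number from compound 3 to compound 4 (0.94 log units; beyond the scatter) in this assay, resting on a 13-fold lower number from compound 1 to compound 2 (1.10 log units; beyond the scatter). The estimate for compound 4 in this assay is 6500 nM, expected to fall between 1500 nM and 28000 nM.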

Compound 4, half-maximal inhibitory concentration: > 100000 nM
Compound 4: no number, only a limit (the forecaster's own chance of this, stated with the estimate: 10%); middle value at least 15-fold (1.18 log units) away from the limit.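

Compound 4 gives > 100000 nM in this assay, which is a limit of the assay and not a number. Methyl in place of hydrogen on this core gives an at least 1.7-fold higher number from compound 3 to compound 4 (0.25 log units; that floor lies within the scatter), so the size of the step past that floor stays unknown, and two cores do not show which difference between them decides the outcome. The step does not carry over from one core to the other in this assay: the same change on two cores in this assay, a 13-fold lower number (1.10 log units; beyond the scatter) from compound 1 to compound 2 and an at least 1.7-fold higher number (0.25 log units; that floor lies within the scatter) from compound 3 to compound 4, at least 22-fold (1.34 log units) apart, beyond the scatter of two such steps

Only two cores are shown, one bearing nitrile groups and one bearing carboxylic acid groups, each with phenyl and 4-methylphenyl, so it stays open how the same change behaves on a core bearing ester or amide groups in their place. Also open, from the compounds shown here alone, is whether an ethyl group or a chlorine atom in place of the methyl follows the step seen on either core.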